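Methyl on the Shared Core: From Compound 3 to Compound 4

This account rests on a few compounds, and the source may have more. Where it says the series, first, only, none or still open, it means among the compounds named here.

Measured so far:
compound 1, `Cc1c(C#Cc2ccc(CCC(=O)O)cc2)ccnc1Cl`, 101%
compound 2, `O=C(O)CCc1ccc(C#Cc2ccnc(Cl)c2)cc1`, 94%
compound 3, `O=C(O)CCc1ccc(C#Cc2ccnc(Cl)n2)cc1`, 131%

All three were tested in an in vitro functional assay on 1321-N1 cells for agonist activity at Free fatty acid receptor 1 (Homo sapiens), read by fluorescence, spectrophotometry and calcium flux; on this read-out higher numbers stand for larger maximal responses and lower numbers for smaller maximal responses. Compound 2 and compound 1 share a core; the difference between the core of compound 2 and that of compound 3 is not broken down here. Compound 3 stands highest of the three, with the nearest neighbour compound 1 well beyond the scatter.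

From compound 2 to compound 1 the change is methyl in place of hydrogen on an aromatic carbon. That step was a number 7 percentage points higher from compound 2 to compound 1 (within the scatter).

Compound 4, `Cc1cnc(Cl)nc1C#Cc1ccc(CCC(=O)O)cc1`, is not yet measured. From compound 3 to compound 4 the change is methyl in place of hydrogen on an aromatic carbon. It is the same kind of change as before, but the place differs: in compound 1 the methyl sits on a ring with 1 nitrogen, ortho to a chloro group, whereas in compound 4 it sits on a ring with 2 nitrogen, para to a chloro group.

Because the earlier step was a number 7 percentage points higher from compound 2 to compound 1 (within the scatter), compound 4 is expected to stay close to compound 3 in this assay, with the expected step being a number 4 percentage points higher from compound 3 to compound 4 (within the scatter). The estimate for compound 4 is 135%, ranging from 110% to 160%.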

Compound 4, largest response reached (reported as efficacy), in percent of the reference or control that the assay uses: 121%
For compound 4 the middle estimate is 14 percentage points above the measured one, and the stated range covers the measured number.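

In this assay, putting methyl in place of hydrogen on an aromatic carbon gave a number 10 percentage points lower from compound 3 to compound 4 (within the scatter). Each step taken alone is too small to separate from repeat scatter, but set side by side they show that this change does not carry from one core to the other as a single fixed amount: the same change on two cores in this assay, a number 7 percentage points higher (within the scatter) from compound 2 to compound 1 and a number 10 percentage points lower (within the scatter) from compound 3 to compound 4, 17 percentage points apart, beyond the scatter of two such steps. This does not show that methyl helps on one core or harms on the other, and it cannot tell whether the gap between the steps follows the core or the place of the methyl, as the two pairs differ in both and two steps give no rule for the whole series.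

The compounds shown leave open how an ethyl group, a methoxy group or an amine at this same place on the core of compound 3 would behave in this assay. They also leave open whether the chloro group could give way to another group, such as a nitrile, and how the methyl step would look then.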